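Phenyl to Thiophen-2-yl: Expected Effect on Paw Edema Inhibition

The source may report more compounds than this note shows. Statements on the series, on what has been measured and on what is new or still open speak of the compounds shown alone.

Of the compounds shown here, two sharing one core have been tested in a functional assay on the whole organism (strain Wistar albino) for inhibition, with Rattus norvegicus as the target, read by paw edema, with stated times of 30 min and 4 h, at a dose of 50 mg/kg by the oral route; on this read-out lower numbers stand for less inhibition and higher numbers for more inhibition at the one dose given (going by the name of the read-out). Compound 1, `NS(=O)(=O)c1ccc2nc(-n3nc(C(F)(F)F)cc3-c3ccc(F)cc3)sc2c1`, gives 50% in this assay. Compound 2, `NS(=O)(=O)c1ccc2nc(-n3nc(C(F)(F)F)cc3-c3ccccc3)sc2c1`, gives 17% in this assay. Among the measured compounds shown here, the single measured step, a number 33 percentage points lower from compound 1 to compound 2 (beyond the scatter), is the only comparison available, and it leaves compound 2 standing lowest of the two numbers, with compound 1 above it by a gap beyond the scatter.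

Compound 3, `NS(=O)(=O)c1ccc2nc(-n3nc(C(F)(F)F)cc3-c3cccs3)sc2c1`, has not yet been measured. Its change from compound 2 is thiophen-2-yl in place of phenyl on an aromatic carbon. For the measured compounds named here, no measured step swaps one ring for another, so nothing directly tells how this change will read. Going by the values given here, the one step that exists, a number 33 percentage points lower from compound 1 to compound 2 (beyond the scatter), concerns only a fluoro on the phenyl ring and shows that this region of the molecule can shift the read-out by a large amount, without saying in which direction a ring swap would go. On that basis the expected step of a number 8 percentage points higher from compound 2 to compound 3 (within the scatter) is modest and uncertain. Compound 3 is therefore estimated at 25%, within a range from 5% to 50%.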

Compound 3, a percentage reported as inhibition, in the whole organism at one dose (the size of the read-out at that dose, not a potency): 15%
Beside the measured number, compound 3's estimate is 10 percentage points above it; the measured number falls inside the stated range.
By their numbers in this assay, from the lowest: compounds 3 and 2 (each within the scatter of the next); then compound 1.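

In this assay, thiophen-2-yl in place of phenyl on this aromatic carbon gives a number 2 percentage points lower from compound 2 to compound 3 (within the scatter), so this first exchange of one ring for another cannot be told apart from the phenyl compound, even though a six-membered carbon ring gives way to a five-membered ring containing sulfur. Thiophen-2-yl in place of 4-fluorophenyl gives a number 35 percentage points lower from compound 1 to compound 3 (beyond the scatter), so among these three compounds only compound 1, the one carrying the fluoro, stands apart, while the two without it sit together whichever ring they carry. The data offer no measurement that explains why the fluorinated compound stands apart.

Going by these compounds, it remains open whether a fluoro on the thiophen-2-yl ring would open a similar gap, and whether the gap belongs to fluoro alone or would also appear with a chloro or methoxy group on the phenyl ring. A six-membered ring containing nitrogen, such as pyridine, or a saturated ring such as cyclohexyl, at this same carbon would also test how far the ring itself can vary.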